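A few compounds are considered here, and "the series" means these few. Any claim that something is new, unique, unknown or untested is made for them only; others in the source may bear on it.

Measured so far in an assay on isolated protein for inhibition of Hematopoietic prostaglandin D synthase (Homo sapiens), read by fluorescence polarization; a higher number here means a weaker inhibitor, a lower number a stronger inhibitor:
compound 1 `O=C(NCc1ccccc1)c1cnc(-c2ccccn2)nc1` gives 7.14 nM
compound 2 `O=C(NCc1ccccc1)c1cnc(-c2ccccc2)nc1` gives 11.7 nM
compound 3 `CC(C)(O)c1nc(-c2cccc(CNC(=O)c3ccc(-c4ccccc4)nc3)c2)no1` gives 27.7 nM

Compound 1 and compound 2 share the core of compound 2 and differ in one place: pyridin-2-yl in place of phenyl on an aromatic carbon The step this change made in this assay is a 1.6-fold lower number from compound 2 to compound 1 (0.21 log units; within the scatter), so the two values are not separated by more than the usual scatter. Compound 3 carries the highest number of the three, standing beyond the scatter from compound 2 and from compound 1; the difference between the core of compound 3 and that of compound 2 is not broken down here.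

Compound 4 `CC(C)(O)c1nc(-c2cccc(CNC(=O)c3ccc(-c4ccccn4)nc3)c2)no1` has not been measured. For the measured compounds named here, it differs from compound 3 by pyridin-2-yl in place of phenyl on an aromatic carbon This is the same kind of change as the one from compound 2 to compound 1, not the same: in compound 1 the new group sits on an aromatic carbon of a six-membered aromatic ring with 2 nitrogen, between two ring nitrogen atoms, whereas in compound 4 it sits on an aromatic carbon of a six-membered aromatic ring with 1 nitrogen, next to the ring nitrogen; in both it is para to a large group.

Going by the values given here, the expected step in this assay is a 1.5-fold lower number from compound 3 to compound 4 (0.19 log units; within the scatter), of about the size seen in a 1.6-fold lower number from compound 2 to compound 1 (0.21 log units; within the scatter), since only that one measured instance of the change is available and it lay within the scatter. Compound 4 is therefore expected to give about 18 nM in this assay. The estimated range for compound 4 runs from 8 nM to 40 nM.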

Compound 4, half-maximal inhibitory concentration: 55.5 nM
For compound 4 the middle estimate is 3.1-fold (0.49 log units) below the measured one; the whole stated range lies below it.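

In this assay, pyridin-2-yl in place of phenyl on an aromatic carbon gives a 2.0-fold higher number from compound 3 to compound 4 (0.30 log units; within the scatter), so taken alone this step does not separate compound 3 from compound 4. Set beside the earlier instance, the change does not carry over with the same effect from one core to the other: the same change on two cores in this assay, a 1.6-fold lower number (0.21 log units; within the scatter) from compound 2 to compound 1 and a 2.0-fold higher number (0.30 log units; within the scatter) from compound 3 to compound 4, 3.3-fold (0.52 log units) apart, beyond the scatter of two such steps. The step measured on the core of compound 2 is therefore a poor guide to the step on the core of compound 3, but with one pair on each core, and each step within the scatter on its own, this does not show a fixed direction for the change on either core, nor which feature of the cores sets the gap.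

Open, from the compounds shown here alone, is whether the gap goes with the ring that carries the new group, a six-membered aromatic ring with 2 nitrogen in compound 1 and with 1 nitrogen in compound 4, or with the rest of the core of compound 3. Also open, going by these compounds, is how a different group in the same place, such as an amine or a carboxylic acid on the pyridin-2-yl ring, would behave on either core.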